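Trimming the Butyl Chain to Ethyl on a Shared Core

The source may hold more compounds than are shown below. What is called first, only, known or untested is meant among the compounds shown, and "the series" means these compounds.

Compound 1 `CCCCNc1nc(C)nc2c1cnn2-c1ccccc1` carries a butylamino group on its core. In a functional assay on G-361 cells (Homo sapiens) for cytotoxicity, read by sulforhodamine B assay (on this read-out higher numbers stand for lower toxicity in this test and lower numbers for higher toxicity in this test), compound 1 gives > 100000 nM, which is a limit of the assay and not a number. Compound 2 `Cc1nc(NCc2ccco2)c2cnn(-c3ccccc3)c2n1` differs from compound 1 by furan-2-yl in place of propyl on a saturated chain carbon bound to a nitrogen on an aromatic ring. In this assay compound 2 gives > 100000 nM, again a limit. The step that the two limits leave unreadable from compound 1 to compound 2 therefore has no readable size. The whole picture is summed up by the limit of > 100000 nM in this assay, at which 2 of the 2 values shown sit.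

Compound 3 `CCNc1nc(C)nc2c1cnn2-c1ccccc1` has not yet been measured in this assay. It differs from compound 1 by hydrogen in place of ethyl on a saturated chain carbon, two bonds along the chain from a nitrogen on an aromatic ring. Going by the values given here, the one measured step, from compound 1 to compound 2, also alters this chain, yet its size stays hidden behind two limits, so no direction can be taken from it. With compound 1 sitting at a limit, the reasonable expectation is that compound 3 also shows no toxicity the assay can put a number to. Compound 3 is estimated at 150000 nM, within a range from 50000 nM to 600000 nM. The step that the limit leaves unreadable from compound 1 to compound 3 is the size expected, that is none beyond the scatter.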

Compound 3, concentration lethal to 50% of the cells: > 100000 nM
Compound 3 was reported as a limit; the forecaster's own chance of this, stated with the estimate: 80%; the middle value lies beyond the limit too.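

Compound 3 also ends at a limit and not a number, so none of the steps linking compound 1, compound 2 and compound 3 can be read, and all three share one picture: the limit of > 100000 nM in this assay, at which 3 of the 3 values shown sit.

The compounds shown leave open whether any change to the chain on the shared core would give a toxicity that can be put as a number.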